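This account rests on a few compounds, and the source may have more. Where it says the series, first, only, none or still open, it means among the compounds named here.

Compound 1, whose structure is `O=C1C=CCC/C1=C\C=C\c1ccccc1`, is a small set's point of reference. Among the measured compounds shown here, in a functional assay on HGC-27 cells (Homo sapiens) for cytotoxicity, read by MTT assay, with a stated time of 72 h (a higher number here means a weaker inhibitor, a lower number a stronger inhibitor), compound 1 gives 4500 nM, which places it second highest of the three numbers measured so far. Its nearest neighbour is compound 3, built as `CC(=O)Oc1ccc(/C=C/C=C2\CCC=CC2=O)cc1`, which in this assay gives 4900 nM; the other measured compound, compound 2, built as `O=C1C=CCC/C1=C\C=C\c1ccc(F)cc1`, gives 2300 nM in this assay. Both companions differ from compound 1 at a single position on the benzene ring, and both of those steps stay within the scatter: a 2.0-fold lower number from compound 1 to compound 2 (0.29 log units; within the scatter) and a 1.1-fold higher number from compound 1 to compound 3 (0.04 log units; within the scatter). For the measured compounds named here, the only step that reaches beyond the scatter is the one between the two substituted compounds, a 2.1-fold higher number from compound 2 to compound 3 (0.33 log units; beyond the scatter), which is modest.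

Compound 4, built as `CN(C)c1ccc(/C=C/C=C2\CCC=CC2=O)cc1`, again changes that one position on the ring: dimethylamino in place of hydrogen on an aromatic carbon. Going by the values given here, no measured step introduces a dimethylamino group, so the closest guide is that fluoro and acetoxy each moved the number only within the scatter. A step of similar modest size, if any, is therefore expected in this assay for compound 4, its direction uncertain; the estimate implies a 1.5-fold lower number from compound 1 to compound 4 (0.18 log units; within the scatter). In this assay compound 4 is expected to give about 3000 nM, within a range from 1200 nM to 8000 nM.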

Compound 4, half-maximal inhibitory concentration: 1500 nM
Estimate against measurement, compound 4: 2.0-fold (0.30 log units) above, within the range that was stated.
By their numbers in this assay, from the lowest: compounds 4, 2, 1 and 3 (each within the scatter of the next, the first and the last beyond it).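

In this assay, this position on the aromatic ring now shows a change that reaches beyond the scatter when measured against hydrogen: putting dimethylamino there gives a 3.0-fold lower number from compound 1 to compound 4 (0.48 log units; beyond the scatter), something neither fluoro nor acetoxy did. Replacing acetoxy with dimethylamino also goes beyond the scatter, with a 3.3-fold lower number from compound 3 to compound 4 (0.51 log units; beyond the scatter), so the number does depend on which group sits at this position, whereas replacing fluoro with dimethylamino gives a 1.5-fold lower number from compound 2 to compound 4 (0.19 log units; within the scatter), which leaves those two groups indistinguishable in this measurement. Nothing available offers an explanation for these differences.

The compounds shown leave open whether the result belongs to dimethylamino specifically or extends to related nitrogen groups, such as a plain amino group, a diethylamino group or a morpholine ring. They also leave open how a methoxy group or a carboxylic acid at this same position would compare, and with only four compounds, each carrying a different group on one shared core, no wider trend across substituents can yet be drawn from these numbers.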